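The source may report more compounds than this note shows. Statements on the series, on what has been measured and on what is new or still open speak of the compounds shown alone.

Measured compounds:
- compound 1, `CCCCCCCC/C=C/CCCCCCCC(=O)O[C@H]1[C@H](O)[C@H](n2ccc(N)nc2=O)O[C@@H]1CO`: 0.05 ug/mL
- compound 2, `CCCCCCCCCCCCCCCCCCCCCC(=O)O[C@H]1[C@H](O)[C@H](n2ccc(N)nc2=O)O[C@@H]1CO`: 1.1 ug/mL
- compound 3, `CCCCCCCCCCCCCCCC(=O)O[C@H]1[C@H](O)[C@H](n2ccc(N)nc2=O)O[C@@H]1CO`: 0.24 ug/mL

In a functional assay on HeLa cells (Homo sapiens) for cytotoxicity, read by cell counting, with a stated time of 48 h (a lower number here means that less compound is needed, a higher number that more compound is needed for the effect), compound 3 stands second highest of the three numbers. Its nearest neighbour is compound 2, a 4.6-fold lower number from compound 2 to compound 3 (0.66 log units; beyond the scatter); its furthest is compound 1, a 4.8-fold higher number from compound 1 to compound 3 (0.68 log units; beyond the scatter).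

The unmeasured compound 4, `CCCCCCCC/C=C\CCCCCCCC(=O)O[C@H]1[C@H](O)[C@H](n2ccc(N)nc2=O)O[C@@H]1CO`, is reached from compound 3 by dec-1-en-1-yl in place of octyl on a saturated chain carbon, seven bonds along the chain from a carbonyl carbon. Among the compounds with values here, the step that bears most directly on this is the one from compound 1 to compound 3, where the shorter saturated group replaced the longer group carrying the double bond at the same place on the chain and the number rose, a 4.8-fold higher number from compound 1 to compound 3 (0.68 log units; beyond the scatter). The change to compound 4 runs the other way: octyl leaves and dec-1-en-1-yl enters. Compound 2, with the longest fully saturated chain, gives the highest number, so plain lengthening alone is not what the data reward; the low number belongs to compound 1, whose chain carries the double bond. A step downward in this assay is therefore expected, a 4.0-fold lower number from compound 3 to compound 4 (0.60 log units; beyond the scatter). Within the data shown here, that expected step is about the size of the one seen from compound 1 to compound 3. Compound 4 is estimated at 0.06 ug/mL, with a range of 0.02 ug/mL to 0.2 ug/mL.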

Compound 4, concentration for half-maximal effect: 0.06 ug/mL
Compound 4: middle estimate and measured number agree at the digits printed, within the range that was stated.
By their numbers in this assay, from the lowest: compounds 1 and 4 (each within the scatter of the next); then compound 3; then compound 2.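

In this assay, dec-1-en-1-yl in place of octyl, on a saturated chain carbon seven bonds along the chain from a carbonyl carbon, now reads a 4.0-fold lower number from compound 3 to compound 4 (0.60 log units; beyond the scatter), so the drop seen earlier with the double bond drawn E also holds with it drawn Z. Configuration of the double bond does not separate the two chains in this assay, with a 1.2-fold higher number from compound 1 to compound 4 (0.08 log units; within the scatter). The low number at this position is therefore not tied to one drawn geometry, and this pair isolates that single feature: the fact that compounds 1 and 4 differ only in the configuration as drawn

Still open, going by these compounds, is how much of the step from octyl to dec-1-en-1-yl belongs to the double bond and how much to the added chain length, a split that a saturated decyl group at this place would speak to directly. Also open, on these data alone, is whether a chain carrying a second double bond, or one ending in a carboxylic acid or an amine, would keep the number near those of compound 1 and compound 4 in this assay.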